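Benzylic ring variation on the thiourea of the shared core

This account rests on a few compounds, and the source may have more. Where it says the series, first, only, none or still open, it means among the compounds named here.

For the measured compounds named here, compound 3 `Nc1ccccc1NC(=O)c1ccc(NC(=S)NCc2cccnc2)cc1` carries the only number in the set: in an assay on isolated protein for inhibition of Nicotinamide phosphoribosyltransferase (Homo sapiens), read by fluorescence, with stated times of 5 min and 15 min (on this read-out higher numbers stand for weaker inhibition and lower numbers for stronger inhibition), compound 3 gives 116 nM. Compound 1 `Nc1ccccc1NC(=O)c1ccc(NC(=S)NCc2ccc(Cl)nc2)cc1` reaches only a limit of the assay; in this assay compound 1 gives > 2000 nM. Compound 2 `Nc1ccccc1NC(=O)c1ccc(NC(=S)NCc2ccccc2F)cc1` likewise reaches only a limit; in this assay compound 2 gives > 2000 nM. Because two of the three values sit at the limit (the limit of > 2000 nM in this assay, at which 2 of the 3 values shown sit), the steps to compound 3 are read as bounds only, and the step that the two limits leave unreadable from compound 1 to compound 2 cannot be sized at all.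

Compound 4 `Nc1ccccc1NC(=O)c1ccc(NC(=S)NCc2cccc(Cl)c2)cc1` differs from compound 3 in one place: 3-chlorophenyl in place of pyridin-3-yl on a saturated chain carbon bound to an amide-type nitrogen. Going by the values given here, two measured steps bear on this change. Removing the pyridine nitrogen in favour of a carbon-only ring is the reverse of an at least 17-fold lower number from compound 2 to compound 3 (1.23 log units; beyond the scatter), and adding a chloro to the ring is the reverse of an at least 17-fold lower number from compound 1 to compound 3 (1.23 log units; beyond the scatter); both directions point the same way, toward a large increase in this assay. Compound 4 is therefore expected to give 2500 nM, within 600 nM to 10000 nM. The expected step is a 22-fold higher number from compound 3 to compound 4 (1.33 log units; beyond the scatter), most likely ending at the limit.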

Compound 4, half-maximal inhibitory concentration: > 2000 nM
Compound 4: only a limit was reported; the forecaster's own chance of this, stated with the estimate: 60%; the middle value is on the limit's open side.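

In this assay, 3-chlorophenyl in place of pyridin-3-yl on a saturated chain carbon bound to an amide-type nitrogen gives an at least 17-fold higher number from compound 3 to compound 4 (1.23 log units; beyond the scatter). Compound 4 thus ends at a limit of the assay, as compound 1 and compound 2 do, and among these four compounds only compound 3, the one whose ring carries no halogen, gives a number; a carbon-only ring with chloro at this place joins 2-fluorophenyl and 6-chloropyridin-3-yl at that limit. The steps among compound 1, compound 2 and compound 4 cannot be read, so these three stay unranked: the limit of > 2000 nM in this assay, at which 3 of the 4 values shown sit.

Still open, going by these compounds, is whether the ring nitrogen or the absence of a halogen matters more, since every ring at the limit carries a halogen; a plain benzyl would separate the two. Also open, on these data alone, is how a methyl or an amine on the pyridin-3-yl ring, or a longer chain to the ring, compares with compound 3.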